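Tert-butoxycarbonyl in place of ethyl: notes on compound 3

The compounds below may be only part of what the source reports. "The series", "measured", "known", "first", "only" and "open" are said of these compounds alone.

In an ADME assay on L02 cells (Homo sapiens) for inhibition, read by CCK-8 assay, with a stated time of 48 h (on this read-out lower numbers stand for stronger inhibition of growth and higher numbers for weaker inhibition of growth), compound 1 (`Cc1ccccc1Nc1nc(Nc2ccc(N3CCN(C)CC3)cc2)ncc1Cl`) gives 6510 nM and compound 2 (`CCN1CCN(c2ccc(Nc3ncc(Cl)c(Nc4ccccc4C)n3)cc2)CC1`) gives 970 nM as the lower of the two numbers. Compound 3 (`Cc1ccccc1Nc1nc(Nc2ccc(N3CCN(C(=O)OC(C)(C)C)CC3)cc2)ncc1Cl`) carries tert-butoxycarbonyl in place of ethyl on an amine nitrogen in a ring. Among the measured compounds shown here, the one measured step at this place (a 6.7-fold lower number from compound 1 to compound 2 (0.83 log units; beyond the scatter)) is modest and brings in a much smaller group, so it guides direction only weakly. No shift beyond the scatter is therefore expected in this assay, with an estimated 1.5-fold higher number from compound 2 to compound 3 (0.19 log units; within the scatter) as the likely size. For compound 3 the estimate is 1500 nM with 350 nM to 7000 nM as the expected range.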

Compound 3, concentration for 50% growth inhibition: 1750 nM
For compound 3 the middle estimate is 1.2-fold (0.07 log units) below the measured one; the measured number falls inside the stated range.
By their numbers in this assay, from the lowest: compounds 2 and 3 (each within the scatter of the next); then compound 1.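

Tert-butoxycarbonyl, with 7 heavy atoms and 2 hydrogen-bond acceptors, replaces ethyl on the amine nitrogen in the ring with a 1.8-fold higher number from compound 2 to compound 3 (0.26 log units; within the scatter) in this assay and so reads alike at this position despite the larger group. Against methyl the same group gives a 3.7-fold lower number from compound 1 to compound 3 (0.57 log units; beyond the scatter) and thus joins ethyl on the lower side of compound 1, so the gain over methyl is not confined to simple alkyl groups. Nothing available explains this behaviour.

As far as these compounds go, whether a free amine hydrogen, an acetyl group or a longer chain bearing a carboxylic acid on this nitrogen would stay level with compound 2 remains open.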